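Ring size at the amide: compound 2 to compound 4

The compounds below may be only part of what the source reports. "The series", "measured", "known", "first", "only" and "open" are said of these compounds alone.

Of the compounds shown here, three have numbers so far. In an assay on the whole organism (plasma, strain Sprague-Dawley) for inhibition of Dipeptidyl peptidase 4 (Rattus norvegicus), with a stated time of 10 h, at a dose of 1 mg/kg by the oral route (a higher number here means more inhibition at the dose given (going by the name of the read-out), a lower number less inhibition), compound 1 `C[C@@H]1N[C@H](C(=O)N2CCC[C@H]2C#N)C[C@@H]1C(=O)N1CCC1` gives 88%. In this assay compound 3 `C[C@@H]1N[C@H](C(=O)N2CCC[C@H]2C#N)C[C@@H]1C(=O)N1CCCCC1` gives 81%. In this assay compound 2 `N#C[C@@H]1CCCN1C(=O)[C@@H]1C[C@H](C(=O)N2CCCCC2)CN1` gives 50%, the lowest of the three numbers; its nearest neighbour is compound 3, and the gap is a number 31 percentage points higher from compound 2 to compound 3 (beyond the scatter). The step of a number 7 percentage points lower from compound 1 to compound 3 (within the scatter) concerns the amide ring alone.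

Compound 4 `N#C[C@@H]1CCCN1C(=O)[C@@H]1C[C@H](C(=O)N2CCC2)CN1` differs from compound 2 in one place: azetidin-1-yl in place of piperidin-1-yl on a carbonyl carbon. Among the measured compounds shown here, the only measured step that bears on this change is a number 7 percentage points lower from compound 1 to compound 3 (within the scatter), which runs in the opposite direction on the methylated core and stays within the scatter. The step from compound 2 to compound 4 is therefore expected to be of the same modest kind, if anything slightly upward, but not beyond the scatter: the estimated step is a number 6 percentage points higher from compound 2 to compound 4 (within the scatter). Compound 4 is thus expected to give 56% in this assay, within a range of 40% to 72%. For the measured compounds named here, no measured pair shows the azetidine ring on the unmethylated core, so this estimate rests on the single step of a number 7 percentage points lower from compound 1 to compound 3 (within the scatter).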

Compound 4, a percentage reported as inhibition, in the whole organism at one dose (the size of the read-out at that dose, not a potency): 46%
Compound 4: middle estimate off by 10 percentage points, on the high side; measured number inside the range.
By their numbers in this assay, from the lowest: compounds 4 and 2 (each within the scatter of the next); then compounds 3 and 1 (each within the scatter of the next).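

In this assay, the change from piperidin-1-yl to azetidin-1-yl on a carbonyl carbon can now be read on the core without the methyl, a number 4 percentage points lower from compound 2 to compound 4 (within the scatter), so this ring change stays small on both cores: the same change on two cores in this assay, a number 7 percentage points lower (within the scatter) from compound 1 to compound 3 and a number 4 percentage points higher (within the scatter) from compound 4 to compound 2, 11 percentage points apart, within the scatter of two such steps

The methyl on a saturated ring carbon, so far read only with piperidin-1-yl on the carbonyl carbon, also carries a large step with azetidin-1-yl, a number 42 percentage points lower from compound 1 to compound 4 (beyond the scatter), and the two readings agree: the same change on two cores in this assay, a number 31 percentage points higher (beyond the scatter) from compound 2 to compound 3 and a number 42 percentage points higher (beyond the scatter) from compound 4 to compound 1, 11 percentage points apart, within the scatter of two such steps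

Among these four compounds, the methyl therefore sets the level at this dose and time: compound 1 and compound 3 lie within the scatter of each other, as do compound 2 and compound 4, and no compound shown goes against this.

Still open, from the compounds shown here alone, is whether pyrrolidin-1-yl, morpholin-4-yl or an open-chain diethylamino group on the same carbonyl carbon would also stay within the scatter. Going by these compounds, it is equally open whether an ethyl or a hydroxymethyl in place of the methyl on the saturated ring carbon would keep the large step.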